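This account rests on a few compounds, and the source may have more. Where it says the series, first, only, none or still open, it means among the compounds named here.

Measured so far in an ADME assay on HepG2 cells (Homo sapiens) for cytotoxicity, read by MTT assay, with a stated time of 48 h, tested at 1 uM; a higher number here means a stronger effect of the compound at the concentration tested, a lower number a weaker effect:

compound 1, `O=c1cc(-c2cccc(O)c2)oc2cc(OCCCCCCCCN3CCCC3)ccc12`: 19%
compound 2, `O=c1cc(-c2ccccc2)oc2cc(OCCCCCCCCN3CCCC3)ccc12`: 11.3%

Among the compounds with values here, compound 2 stands at the lower of the two numbers in this assay, with compound 1 as its only neighbour; the step of a number 7.7 percentage points lower from compound 1 to compound 2 (within the scatter) lies within the scatter, so the two values cannot be ranked against each other.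

Compound 3, `O=c1cc(-c2ccccc2O)oc2cc(OCCCCCCCCN3CCCC3)ccc12`, is not yet measured. It differs from compound 2 by hydroxy in place of hydrogen on an aromatic carbon.

Within the data shown here, the only measured step that bears on this is the one between compound 1 and compound 2, where a hydroxy on the same six-membered aromatic ring of carbon only was exchanged for hydrogen; that step stayed within the scatter. Putting a hydroxy back on that ring, here on a different aromatic carbon, is therefore expected to give a change of about a number 3.7 percentage points higher from compound 2 to compound 3 (within the scatter), that is, none beyond the scatter.

Compound 3 is estimated at 15% in this assay, with a range from 5% to 28%.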

Compound 3, a percentage reported as inhibition, at one concentration (the size of the read-out at that concentration, not a potency): 5.92%
For compound 3 the middle estimate is 9.1 percentage points above the measured one; measured number inside the range.
By their numbers in this assay, from the lowest: compounds 3, 2 and 1 (each within the scatter of the next, the first and the last beyond it).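

In this assay, phenyl to 2-hydroxyphenyl, with the hydroxy ortho to a large group, gives a step that stays within the scatter (a number 5.4 percentage points lower from compound 2 to compound 3 (within the scatter)), so this change alone cannot be read as moving the value. The comparison between the two hydroxy compounds is the first to pass the scatter (a number 13.1 percentage points lower from compound 1 to compound 3 (beyond the scatter)), though only modestly: among these three compounds, the place of the hydroxy on the ring separates two values, whereas neither step between a hydroxy compound and compound 2 does. Nothing available explains this difference.

On these data alone, it remains open whether a methoxy or an amine on the same carbon would give a value nearer compound 3 or compound 1. As far as these compounds go, it also remains open whether the gap between the two hydroxy places would persist with a shorter chain.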